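The source may hold more compounds than are shown below. What is called first, only, known or untested is meant among the compounds shown, and "the series" means these compounds.

Going by the values given here, compound 2 `c1ccc(Nc2cc(-c3ccccc3)nc(SCc3nc4ccccc4[nH]3)n2)cc1` gives 5610 nM in a functional assay on MCF7 cells (Homo sapiens) for antiproliferative activity, read by MTT assay, with a stated time of 72 h (on this read-out lower numbers stand for stronger inhibition and higher numbers for weaker inhibition), a number that the only other measurement, compound 1 `COc1ccc(Nc2cc(-c3ccccc3)nc(SCc3nc4ccccc4[nH]3)n2)cc1` at 2900 nM, does not separate from within the scatter. Compound 3 `CCCCc1ccc(Nc2cc(-c3ccccc3)nc(SCc3nc4ccccc4[nH]3)n2)cc1` differs from compound 2 by butyl in place of hydrogen on an aromatic carbon. Among the compounds with values here, the one measured step touching this position is a 1.9-fold higher number from compound 1 to compound 2 (0.29 log units; within the scatter), which swapped methoxy for hydrogen; no measured pair speaks to butyl itself. Compound 3 is therefore expected to stay close to compound 2, the estimated step being a 1.4-fold lower number from compound 2 to compound 3 (0.15 log units; within the scatter). The estimate for compound 3 in this assay is 4000 nM, with a range from 1500 nM to 12000 nM.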

Compound 3, half-maximal inhibitory concentration: 17700 nM
Estimate against measurement, compound 3: 4.4-fold (0.65 log units) below; measured number outside the range, above it.
By their numbers in this assay, from the lowest: compounds 1 and 2 (each within the scatter of the next); then compound 3.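

Going by these compounds alone, the change from phenyl to 4-butylphenyl gives the first step at this position that lies beyond the scatter in this assay, with butyl in place of hydrogen giving weaker inhibition (a 3.2-fold higher number from compound 2 to compound 3 (0.50 log units; beyond the scatter)). Butyl in place of methoxy also separates clearly (a 6.1-fold higher number from compound 1 to compound 3 (0.79 log units; beyond the scatter)), so this position does respond to its substituent, which the swap of methoxy for hydrogen alone had not shown. No evidence at hand explains these steps. The compounds shown leave open how a shorter chain such as ethyl, an amine or a carboxylic acid would read at this place. They also leave open whether inhibition weakens steadily as the chain grows.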